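A chloro group on the core of compound 1

The source may report more compounds than this note shows. Statements on the series, on what has been measured and on what is new or still open speak of the compounds shown alone.

Among the measured compounds shown here, compound 1 `COc1ccc(N(C)c2ncnc3c2ncn3Cc2cc(OC)cc(OC)c2)cc1` gives 42000 nM in a functional assay on K562 cells (Homo sapiens) for antiproliferative activity, read by MTT assay, with a stated time of 48 h (a lower number here means a stronger inhibitor of growth, a higher number a weaker inhibitor of growth), the only exact number available so far. Compound 2 `COc1ccc(N(C)c2ncnc3c2ncn3Cc2cc(OC)c(OC)c(OC)c2)cc1` reads > 100000 nM, which is a limit of the assay and not a number.

Compound 3 `COc1ccc(N(C)c2nc(Cl)nc3c2ncn3Cc2cc(OC)cc(OC)c2)cc1` keeps the core of compound 1 and differs by one change: chloro in place of hydrogen on an aromatic carbon. The chloro group takes the place of a hydrogen on an aromatic carbon, between two ring nitrogen atoms.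

For the measured compounds named here, only one measured step is available for comparison: an at least 2.3-fold higher number from compound 1 to compound 2 (0.37 log units; beyond the scatter). It comes from a methoxy in place of hydrogen on an aromatic carbon, at a different place in the molecule. It shows that one added group moved the number beyond the scatter here, but it gives little guidance on direction for the chloro change. The size of that step is therefore only a rough guide, and the lean towards a lower number in this assay is tentative. The expected change is a 3.5-fold lower number from compound 1 to compound 3 (0.54 log units; beyond the scatter). For compound 3 the estimated value is 12000 nM, with an expected range from 1500 nM to 60000 nM.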

Compound 3, concentration for 50% growth inhibition: 42000 nM
Estimate against measurement, compound 3: 3.5-fold (0.54 log units) below; the range from low to high includes it.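

In this assay, placing chloro on the aromatic carbon between two ring nitrogen atoms of the shared core gives no change at the digits printed from compound 1 to compound 3 (within the scatter). Among the compounds shown here, this is the first reading at this position, and it shows that one chlorine atom here can replace hydrogen without moving the number outside normal assay variation, whereas the earlier change, a methoxy added at a different place, gave an at least 2.3-fold higher number from compound 1 to compound 2 (0.37 log units; beyond the scatter). The new comparison rests on two exact numbers, while compound 2 alone reads as a limit of the assay and not a number: the limit of > 100000 nM in this assay, at which 1 of the 3 values shown sits.

As far as these compounds go, a single substituent says little about the position as a whole, so it remains open whether an amine, a carboxylic acid or a longer carbon chain at this same carbon would also leave the number unchanged or would shift it in either direction. From the compounds shown here alone, it is also open whether chloro would have the same outcome on the core of compound 2, or whether the result in K562 cells would carry over to other cell lines.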